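Swapping Pyrrolidine for Fluorine: An Untested Analogue

This account rests on a few compounds, and the source may have more. Where it says the series, first, only, none or still open, it means among the compounds named here.

The compounds here share one core, shown in compound 1 `O=C(/C=C/c1ccc(N2CCCC2)cc1)c1ccc(O)cc1`. Among the measured compounds shown here, in a functional assay on SNU-638 cells (Homo sapiens) for cytotoxicity, read by MTT assay (a lower number here means a stronger inhibitor, a higher number a weaker inhibitor), compound 1 gives 620 nM, the lowest of the two numbers measured so far; its nearest neighbour, compound 3 `O=C(/C=C/c1ccc(N2CCCC2)cc1)c1ccc(O)cc1O`, gives 5770 nM. Compound 2 `O=C(/C=C/c1ccc(N2CCCC2)cc1)c1ccc(F)cc1` reaches only the limit of the measurement, > 25000 nM, so no number is known for it. Two single-point changes from compound 1 have been measured. The first: an at least 40-fold higher number from compound 1 to compound 2 (1.60 log units; beyond the scatter). The second: a 9.3-fold higher number from compound 1 to compound 3 (0.97 log units; beyond the scatter). Both changes sit on the ring that carries the hydroxy group, and both weaken the compound beyond the scatter.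

Compound 4 `O=C(/C=C/c1ccc(F)cc1)c1ccc(O)cc1` has not been measured. It differs from compound 1 in fluoro in place of pyrrolidin-1-yl on an aromatic carbon, a change on the other ring. For the measured compounds named here, no measured step touches that ring, so the two measured steps guide only loosely: they show that every alteration of compound 1 tried so far has cost potency, once modestly and once heavily. A weakening of roughly the same order as the modest step is therefore expected, placed at a 13-fold higher number from compound 1 to compound 4 (1.11 log units; beyond the scatter). Compound 4 is thus estimated at 8000 nM, with a range from 1500 nM to 30000 nM.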

Compound 4, half-maximal inhibitory concentration: 5540 nM
Compound 4: middle estimate off by 1.4-fold (0.16 log units), on the high side; measured number inside the range.
By their numbers in this assay, from the lowest: compound 1; then compounds 4 and 3 (each within the scatter of the next). At a limit, above all of these: compound 2.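

In this assay, among the compounds shown here, exchanging pyrrolidin-1-yl for fluoro gives an 8.9-fold higher number from compound 1 to compound 4 (0.95 log units; beyond the scatter), the only measured step on this six-membered aromatic ring of carbon, so potency depends on this ring as well as on the one carrying the hydroxy group. The pyrrolidin-1-yl group is not needed for a measurable number, as compound 4 gives 5540 nM with a single fluorine in its place, yet keeping it goes with the lower number of compound 1 at 620 nM. Nothing in the available evidence explains the size of this step.

As far as these compounds go, a single exchange cannot separate what is lost with pyrrolidin-1-yl from what is gained with fluoro, so it remains open whether the nitrogen, the five-membered ring or the whole size of the group accounts for the difference. An open-chain amine such as dimethylamino, a morpholine ring or a methoxy group at this place would help to divide these possibilities, since each keeps some parts of pyrrolidin-1-yl and drops others.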